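A few compounds are considered here, and "the series" means these few. Any claim that something is new, unique, unknown or untested is made for them only; others in the source may bear on it.

Compound 1, `CC(c1ccc(-c2ccccc2)c(F)c1)c1nnc2n1N=C(c1ccc(C(F)(F)F)cc1)CS2`, and compound 2, `COc1ccc(C2=Nn3c(nnc3C(C)c3ccc4cc(OC)ccc4c3)SC2)cc1`, share the same core and were both tested in a functional assay on HCT-116 cells (Homo sapiens) for inhibition, read by sulforhodamine B assay, with a stated time of 72 h; a higher number here means a weaker inhibitor, a lower number a stronger inhibitor. In this assay compound 1 gives 6100 nM, and compound 2 gives 6500 nM. Compound 1 stands at the lowest of the two numbers shown, but compound 2 lies within the scatter of it, so the two cannot be told apart on these data.

Compound 3, `Cc1ccc(C2=Nn3c(nnc3C(C)c3ccc(-c4ccccc4)c(F)c3)SC2)cc1`, differs from compound 1 in one place: methyl in place of trifluoromethyl on an aromatic carbon. Going by the values given here, no measured pair shows this same change, so there is no step to lean on, only the two values at hand. The step of a 1.2-fold higher number from compound 1 to compound 3 (0.09 log units; within the scatter) is expected to be small, with no clear direction beyond the scatter. On that basis compound 3 is estimated in this assay at 7500 nM, with a range from 2500 nM to 22000 nM.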

Compound 3, half-maximal inhibitory concentration: 4800 nM
Compound 3: the middle estimate sits 1.6-fold (0.19 log units) above what was measured, and the stated range covers the measured number.
By their numbers in this assay, from the lowest: compounds 3, 1 and 2 (each within the scatter of the next).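

In this assay, going by these compounds alone, the change from 4-(trifluoromethyl)phenyl to 4-methylphenyl gives a 1.3-fold lower number from compound 1 to compound 3 (0.10 log units; within the scatter) and so provides the first direct comparison at this position, where the shared core and the rest of the molecule stay the same. The two groups cannot be told apart on these numbers, so this position accepts either one without a measurable shift in this cell assay. No other measurement here helps to explain this result.

As far as these compounds go, this is a single pair, so it remains unknown whether the same swap would behave alike on compound 2 or any other compound. From the compounds shown here alone, it also remains open whether a different group at this place, such as an amine or a carboxylic acid, would move the number beyond the scatter.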